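The compounds below may be only part of what the source reports. "The series", "measured", "known", "first", "only" and "open" are said of these compounds alone.

Working notes on the arylsulfonyl series built on the core of compound 1 `CCn1cc(C(=O)O)c(=O)c2cc(F)c(N3CCN(C(=N)NS(=O)(=O)c4ccc(C(F)(F)F)cc4)CC3)cc21`. In a functional assay on A549 cells (Homo sapiens) for antiproliferative activity, read by MTT assay, with a stated time of 72 h (a higher number here means a weaker inhibitor, a lower number a stronger inhibitor), compound 1 gives 71 nM. Compound 2 `CCn1cc(C(=O)O)c(=O)c2cc(F)c(N3CCN(C(=N)NS(=O)(=O)c4cccc(Cl)c4)CC3)cc21` gives 71 nM, and compound 3 `CCn1cc(C(=O)O)c(=O)c2cc(F)c(N3CCN(C(=N)NS(=O)(=O)c4ccccc4C(F)(F)F)CC3)cc21` gives 71 nM, so compound 3 stands level with the other two.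

The open entry is compound 4 `CCn1cc(C(=O)O)c(=O)c2cc(F)c(N3CCN(C(=N)NS(=O)(=O)c4ccc(Cl)cc4)CC3)cc21`, which differs from compound 3 as follows: 4-chlorophenyl in place of 2-(trifluoromethyl)phenyl on a sulfonyl sulfur. In short, 4-chlorophenyl replaces 2-(trifluoromethyl)phenyl on a sulfonyl sulfur.

All three measured steps bear on this change, since each swaps one aryl group for another at that same sulfonyl sulfur. They read no change at the digits printed from compound 1 to compound 2 (within the scatter), no change at the digits printed from compound 1 to compound 3 (within the scatter) and no change at the digits printed from compound 2 to compound 3 (within the scatter). The entering group carries the chlorine of the 3-chlorophenyl in compound 2 and the numbering of the 4-(trifluoromethyl)phenyl in compound 1, and neither compound departs from compound 3 in value. The evidence is thin, covering only these three compounds, and none of them carries the 4-chlorophenyl group itself. No shift beyond the scatter is expected in this assay, in either direction.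

The expected step is no change at the digits printed from compound 3 to compound 4 (within the scatter). The estimate for compound 4 is 71 nM, with an expected range of 32 nM to 160 nM.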

Compound 4, half-maximal inhibitory concentration: 71 nM
Compound 4: the middle estimate sits on the measured number at the digits printed; the range from low to high includes it.
By their numbers in this assay, from the lowest: compounds 1, 2, 3 and 4 (each within the scatter of the next).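

In this assay, for the compounds shown here, the exchange of chloro for trifluoromethyl on an aromatic carbon now stands as a single change on an otherwise unaltered aryl group, and it reads as (no change at the digits printed from compound 1 to compound 4 (within the scatter)), a comparison that the earlier compounds did not offer. The 3-chlorophenyl and 4-chlorophenyl groups on the sulfonyl sulfur can also now be set directly against each other (no change at the digits printed from compound 2 to compound 4 (within the scatter)), and the exchange of 2-(trifluoromethyl)phenyl for 4-chlorophenyl gives the same reading (no change at the digits printed from compound 3 to compound 4 (within the scatter)), so the four aryl groups shown cannot be told apart in this assay. Nothing among the data given accounts for this flat reading.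

Every aryl group shown carries either chloro or trifluoromethyl, so it remains open whether an unsubstituted phenyl, a methoxy-bearing or amine-bearing phenyl, or a simple methyl or longer alkyl chain on the sulfonyl sulfur would stay within the scatter in this assay. Going by these compounds, it also remains open how the series would read with an amide in place of the carboxylic acid on the shared core.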